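From 4-fluorophenyl to 2-chlorophenyl on a sulfur

The source may hold more compounds than are shown below. What is called first, only, known or untested is meant among the compounds shown, and "the series" means these compounds.

In a functional assay on A549 cells (Homo sapiens) for antiproliferative activity, read by MTT assay, with a stated time of 72 h (a lower number here means a stronger inhibitor, a higher number a weaker inhibitor), compound 1 `S=C(Sc1ccccc1)N1CCOCC1` gives 2520 nM and compound 2 `CC(C)(C)OC(=O)N1CCN(C(=S)Sc2ccc(F)cc2)CC1` gives 1560 nM (so compound 2 stands within the usual scatter of compound 1 and the pair cannot be ranked). Compound 3 `CC(C)(C)OC(=O)N1CCN(C(=S)Sc2ccccc2Cl)CC1` has 2-chlorophenyl in place of 4-fluorophenyl on a sulfur and awaits measurement. Among the measured compounds shown here, no measured pair isolates such a change, so no shift beyond the scatter is expected in this assay in either direction. What is expected is a 1.1-fold higher number from compound 2 to compound 3 (0.04 log units; within the scatter) (an estimate only). For compound 3 the estimated value is 1700 nM (expected range 700 nM to 4200 nM).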

Compound 3, half-maximal inhibitory concentration: 1560 nM
Compound 3: the middle estimate sits 1.1-fold (0.04 log units) above what was measured; measured number inside the range.
By their numbers in this assay, from the lowest: compounds 2, 3 and 1 (each within the scatter of the next).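

In this assay, 2-chlorophenyl in place of 4-fluorophenyl on a sulfur gives no change at the digits printed from compound 2 to compound 3 (within the scatter), the first step shown that isolates a single change at this place. The sulfur thus carries either of these two halogen-bearing phenyl groups with no readable shift, though this holds for this pair alone. No measurement here offers an explanation for this result. From the compounds shown here alone, it remains open whether an aminophenyl group, a carboxylic acid or a longer alkyl chain on this sulfur would shift the number beyond the scatter.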